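The compounds below may be only part of what the source reports. "The series", "measured", "known", "first", "only" and "open" are said of these compounds alone.

Measured compounds:
compound 1 `O=C(Nn1c(-c2cccc([N+](=O)[O-])c2)nc2c(-c3ccc(Cl)cc3)n[nH]c2c1=O)c1ccccc1` — 87.8%
compound 2 `COc1cccc(-c2nc3c(-c4ccc(Cl)cc4)n[nH]c3c(=O)n2NC(=O)c2ccccc2)c1` — 87.3%
compound 3 `COc1cccc(Cc2nc3c(-c4ccc(Cl)cc4)n[nH]c3c(=O)n2NC(=O)c2ccccc2)c1` — 89.3%

In a functional assay on HT-29 cells (Homo sapiens) for cytotoxicity, read by sulforhodamine B assay, with a stated time of 2 days, tested at 100 uM (on this read-out lower numbers stand for less inhibition and higher numbers for more inhibition at the one concentration tested (going by the name of the read-out)), compound 3 stands highest of the three numbers, but its margin is small: a number 1.5 percentage points higher from compound 1 to compound 3 (within the scatter) and a number 2 percentage points higher from compound 2 to compound 3 (within the scatter) both lie within the scatter, so the three compounds are not told apart. Among the compounds with values here, the only other step, a number 0.5 percentage points lower from compound 1 to compound 2 (within the scatter), is likewise within the scatter. The series thus far reads as flat.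

Compound 4 `O=C(Nn1c(CCc2ccccc2)nc2c(-c3ccc(Cl)cc3)n[nH]c2c1=O)c1ccccc1` is not yet measured. The change from compound 3 is benzyl in place of 3-methoxyphenyl on a saturated chain carbon bound to an aromatic carbon. Within the data shown here, two measured steps touch the same region of the structure: the exchange of a substituent on this aromatic ring, seen in a number 0.5 percentage points lower from compound 1 to compound 2 (within the scatter), and the lengthening of the link between the core and the ring, seen in a number 2 percentage points higher from compound 2 to compound 3 (within the scatter); neither moved the read-out beyond the scatter. With both kinds of change producing no real shift, no step beyond the scatter is expected in this assay for compound 4.

Compound 4 is therefore estimated at 87%, with a range of 78% to 95%, meaning an expected step of a number 2.3 percentage points lower from compound 3 to compound 4 (within the scatter).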

Compound 4, a percentage reported as inhibition, at one concentration (the size of the read-out at that concentration, not a potency): 86.5%
For compound 4 the middle estimate is 0.5 percentage points above the measured one, within the range that was stated.
By their numbers in this assay, from the lowest: compounds 4, 2, 1 and 3 (each within the scatter of the next).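

In this assay, phenethyl in place of 3-methoxybenzyl gives a number 2.8 percentage points lower from compound 3 to compound 4 (within the scatter), in place of 3-methoxyphenyl it gives a number 0.8 percentage points lower from compound 2 to compound 4 (within the scatter), and in place of 3-nitrophenyl it gives a number 1.3 percentage points lower from compound 1 to compound 4 (within the scatter). The earlier compounds shown here all carried a methoxy or nitro group on this ring, whereas compound 4 carries neither, and it still cannot be told apart from any of them on this read-out. Nothing available bears on why these compounds read alike.

Going by these compounds, whether an amine or a carboxylic acid on this ring, or a chain longer than phenethyl, would give a step beyond the scatter remains open. With a single tested concentration, the four compounds also leave open whether they would separate at lower concentrations.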